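Cyclopentyl in Place of Ethyl on the Amide of Compound 1

The source may hold more compounds than are shown below. What is called first, only, known or untested is meant among the compounds shown, and "the series" means these compounds.

Compound 1 `CCC(=O)Nc1ncc(-c2ccc(OC)cc2)n1C` was examined in a toxicity assay on THP-1 cells (Homo sapiens) for inhibition; on this read-out higher numbers stand for lower toxicity in this test and lower numbers for higher toxicity in this test. In this assay compound 1 gives > 100000 nM, which is a limit of the test rather than a number. Compound 2 `COc1ccc(-c2ccnc(NC(=O)c3ccc(F)cc3)c2)cc1` in this assay gives > 100000 nM, again a limit. Compound 3 `CCn1c(-c2ccc(OC)cc2)cnc1NC(=O)c1ccc(F)cc1` in this assay likewise gives > 100000 nM, once more a limit. Compound 1 therefore stands where the two other measured compounds stand: the limit of > 100000 nM in this assay, at which 3 of the 3 values shown sit. Among the compounds with values here, none of these three compounds differs from another in only one place, so no measured step between them can be sized, and the three limits give no direction for any change at all.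

Compound 4 `COc1ccc(-c2cnc(NC(=O)C3CCCC3)n2C)cc1` is not yet measured in this assay. It differs from compound 1 by cyclopentyl in place of ethyl on a carbonyl carbon. With every measured value sitting at the limit, there is nothing in the data to suggest that this change should move the result by more than the usual scatter, in either direction. The step expected from this estimate, a number no higher from compound 1 to compound 4 (the limit leaves the size open), lies within that scatter. Compound 4 is accordingly expected to give about 100000 nM in this assay, with an estimated range from 50000 nM to 200000 nM, and most probably only a limit will again be reported.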

Compound 4, half-maximal cytotoxic concentration: > 100000 nM
Compound 4 was reported as a limit (the forecaster's own chance of this, stated with the estimate: 85%); the middle value lies on the limit itself.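

Compound 1 and compound 4 are both reported only as limits, so no step between them can be read in this assay: the limit of > 100000 nM in this assay, at which 4 of the 4 values shown sit.

The compounds shown leave open at what concentration, if any, toxicity would appear in this assay, and whether cyclopentyl in place of ethyl on a carbonyl carbon changes the read-out at all.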